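A few compounds are considered here, and "the series" means these few. Any claim that something is new, unique, unknown or untested is made for them only; others in the source may bear on it.

Three compounds share one core and differ at a single position. Compound 1 `Cc1nc(NCCCNS(C)(=O)=O)nc2ccc(NC(=O)/C=C/c3ccc(OC(F)(F)F)cc3)cc12` gives 58% in an ADME assay on microsomes from liver (Mus musculus) for metabolic stability, with a stated time of 30 min; on this read-out lower numbers stand for a less stable compound and higher numbers for a more stable compound. Compound 2 `Cc1nc(N2CCC(N3CCCC3=O)CC2)nc2ccc(NC(=O)/C=C/c3ccc(Cl)cc3)cc12` gives 83%, and compound 3 `Cc1nc(N2CCC(N3CCOC3=O)CC2)nc2ccc(NC(=O)/C=C/c3ccc(OC(F)(F)F)cc3)cc12` gives 74%, the second highest of the three; compound 2 lies within the scatter of it, while compound 1 lies beyond the scatter below it. The unmeasured compound 4 `Cc1nc(N2CCC(N3CCCC3=O)CC2)nc2ccc(NC(=O)/C=C/c3ccc(OC(F)(F)F)cc3)cc12` differs from compound 3 by 2-oxopyrrolidin-1-yl in place of 2-oxo-1,3-oxazolidin-3-yl on a saturated ring carbon. Within the data shown here, the only measured step at this position, a number 16 percentage points higher from compound 1 to compound 3 (beyond the scatter), swaps a different group and so bears only loosely on this change; compound 2, which already carries the entering group, shows 83%. The step from compound 3 to compound 4 is therefore expected to be a number 4 percentage points higher from compound 3 to compound 4 (within the scatter), within the scatter. Compound 4 is estimated at 78%, between 62% and 92%.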

Compound 4, percent of the compound remaining: 85%
Estimate against measurement, compound 4: 7 percentage points below, within the range that was stated.
By their numbers in this assay, from the lowest: compound 1; then compounds 3, 2 and 4 (each within the scatter of the next, the first and the last beyond it).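

In this assay, 2-oxopyrrolidin-1-yl in place of 2-oxo-1,3-oxazolidin-3-yl gives a number 11 percentage points higher from compound 3 to compound 4 (beyond the scatter), so this small change within the ring matters on its own. With 2-oxopyrrolidin-1-yl in place, trifluoromethoxy in place of chloro gives a number 2 percentage points higher from compound 2 to compound 4 (within the scatter), while the full swap from the (3-(methanesulfonamido)propyl)amino chain gives a number 27 percentage points higher from compound 1 to compound 4 (beyond the scatter). Nothing measured here explains these steps. On these data alone, it remains open how an amine or a carboxylic acid on the same saturated ring carbon would compare with 2-oxopyrrolidin-1-yl.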